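Swapping benzoyl for (pyridin-4-yl)carbonyl on the ring amide

This account rests on a few compounds, and the source may have more. Where it says the series, first, only, none or still open, it means among the compounds named here.

Measured compounds:
compound 1 `O=C(Nc1n[nH]c2c1CN(C(=O)c1ccccc1)C2)c1ccccc1`, 6400 nM;
compound 2 `CC(=O)n1nc(NC(=O)c2ccccc2)c2c1CN(C(=O)c1ccccc1)C2`, 580 nM;
compound 3 `O=C(Nc1nn(C(=O)C2CC2)c2c1CN(C(=O)c1ccccc1)C2)c1ccccc1`, 1240 nM.

These three compounds share one core and were tested in a functional assay on HCT-116 cells (Homo sapiens) for cytotoxicity, read by sulforhodamine B assay, with a stated time of 48 h; on this read-out lower numbers stand for stronger inhibition and higher numbers for weaker inhibition. Compound 2 gives the lowest number of the three: the step of an 11-fold lower number from compound 1 to compound 2 (1.04 log units; beyond the scatter) is large, and the step of a 2.1-fold higher number from compound 2 to compound 3 (0.33 log units; beyond the scatter) is modest, so compound 2 stands at the strong end of this small set, with compound 3 next and compound 1 furthest away. The step of a 5.2-fold lower number from compound 1 to compound 3 (0.71 log units; beyond the scatter) is modest as well.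

Compound 4 `CC(=O)n1nc(NC(=O)c2ccccc2)c2c1CN(C(=O)c1ccncc1)C2` is not yet measured. It differs from compound 2 in one place: pyridin-4-yl in place of phenyl on a carbonyl carbon. None of the three measured steps bears on this change; all of them concern the acyl group on the aromatic nitrogen, and the benzoyl on the amide-type nitrogen in the ring is kept the same throughout. Going by the values given here, there is therefore no step from which the effect of this change can be read off.

On that basis the expectation for compound 4 is a number close to that of compound 2, with the estimated step of a 1.6-fold higher number from compound 2 to compound 4 (0.19 log units; within the scatter) within or only just beyond the scatter. Compound 4 is estimated at 900 nM, with a range from 300 nM to 3000 nM.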

Compound 4, half-maximal inhibitory concentration: 10000 nM
Beside the measured number, compound 4's estimate is 11-fold (1.05 log units) below it; the whole stated range lies below it.
By their numbers in this assay, from the lowest: compound 2; then compound 3; then compounds 1 and 4 (each within the scatter of the next).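

In this assay, the benzoyl on the amide-type nitrogen in the ring proves far from a silent part of the molecule: pyridin-4-yl in place of phenyl on that carbonyl carbon gives a 17-fold higher number from compound 2 to compound 4 (1.24 log units; beyond the scatter) and so counts as a large step, although the heavy-atom count stays the same and the only counted differences are one ring carbon exchanged for nitrogen and one added hydrogen-bond acceptor. The earlier compounds shown here varied only the acyl group on the aromatic nitrogen, and this result shows that the group on the ring amide can also move the number by a large step, as the acetyl did in an 11-fold lower number from compound 1 to compound 2 (1.04 log units; beyond the scatter) at the other site. Nothing measured here explains the change at the ring amide.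

The compounds shown leave open whether other groups on this carbonyl carbon, such as thiophen-2-yl or cyclohexyl, would stay close to phenyl or follow pyridin-4-yl. They also leave open whether the same swap would have a step of similar size with cyclopropylcarbonyl or hydrogen on the aromatic nitrogen.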